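Trimming a Glutamic Acid Side Chain in a Tail Flick Series

The source may report more compounds than this note shows. Statements on the series, on what has been measured and on what is new or still open speak of the compounds shown alone.

Measured so far:
- compound 1, `O=C(O)CC[C@H](NC(=O)CN(c1nc(Cl)nc2[nH]cnc12)C1CC1)C(=O)O`: 26.8%
- compound 2, `O=C(CN(c1ncnc2c1ncn2C1CCCCO1)C1CC1)N[C@@H](CC(=O)OCc1ccccc1)C(=O)OCc1ccccc1`: 31.8%
- compound 3, `CC(C)C[C@H](NC(=O)CN(c1nc(Cl)nc2[nH]cnc12)C1CC1)C(=O)OCc1ccccc1`: 33.9%

In a functional assay on the whole organism (Tail, strain ICR) with Mus musculus as the target, in the tail flick test, with a stated time of 30 min, at a dose of 25 umol/kg by the oral route (on this read-out higher numbers stand for a stronger effect at the one dose given and lower numbers for a weaker effect), compound 1 gives 26.8%, the lowest of the three numbers, yet both compound 2 and compound 3 lie within the usual scatter of it, so no order among them can be read. Compound 4, `C[C@H](NC(=O)CN(c1nc(Cl)nc2[nH]cnc12)C1CC1)C(=O)O`, is not yet measured. It differs from compound 1 in one place: hydrogen in place of carboxymethyl on a saturated chain carbon, two bonds along the chain from an amide-type nitrogen and a carbonyl carbon. For the measured compounds named here, no measured pair shows this change, so there is nothing to say which way it moves the read-out. Given that all three measured numbers sit close together, the step from compound 1 to compound 4 is expected to be small, a number 2.2 percentage points higher from compound 1 to compound 4 (within the scatter), and not beyond the scatter. For compound 4 in this assay the estimate is 29%, within 15% to 44%.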

Compound 4, a percentage reported as activity, at one dose (the size of the read-out at that dose, not a potency): 48.1%
Beside the measured number, compound 4's estimate is 19.1 percentage points below it, and the stated range ends below it.
By their numbers in this assay, from the lowest: compounds 1, 2 and 3 (each within the scatter of the next); then compound 4.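

For the compounds shown here, changing the group on this saturated chain carbon can shift the read-out of this assay: hydrogen in place of carboxymethyl gives a number 21.3 percentage points higher from compound 1 to compound 4 (beyond the scatter) and is the first single change here to clear the scatter. At this one dose, the 2-carboxyethyl chain of compound 1 is therefore not needed for the effect, since compound 4 with only a methyl scores higher. Nothing available explains the rise. On these data alone, it remains open whether an ethyl chain or an amine at this carbon would keep the higher number. As far as these compounds go, the effect of the change at other doses also remains open.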